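The source may report more compounds than this note shows. Statements on the series, on what has been measured and on what is new or still open speak of the compounds shown alone.

Of the compounds shown here, two have so far been measured in an ADME assay on the whole organism for inhibition, with Oryza sativa as the target, with a stated time of 4 days; on this read-out lower numbers stand for stronger inhibition and higher numbers for weaker inhibition. Compound 1 `CCN(c1nc(Cl)nc(N[C@H](C)c2ccccc2)n1)C(C)C` gives 3550 nM, the lowest of the two numbers. Compound 2 `CCCCNc1nc(Cl)nc(N[C@@H](C)c2ccccc2)n1` gives 23400 nM, which lies beyond the scatter above compound 1. Compound 3 `CCN(c1nc(Cl)nc(N[C@@H](C)c2ccccc2)n1)C(C)C` is not yet measured. Its difference from compound 1: the two compounds have the same atoms and bonds and differ only in configuration as drawn: 1 of 1 stereo elements differ; a stereocentre at a saturated chain carbon is drawn R in compound 1 and S in compound 3. For the measured compounds named here, no measured pair shows this change by itself, so its size is unknown. The step from compound 1 to compound 3 is expected to be a 2.5-fold higher number from compound 1 to compound 3 (0.40 log units; beyond the scatter), toward weaker inhibition, beyond the scatter. Compound 3 is therefore expected to give about 9000 nM, within a range of 2500 nM to 40000 nM.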

Compound 3, half-maximal inhibitory concentration: 537 nM
For compound 3 the middle estimate is 17-fold (1.22 log units) above the measured one, and the stated range ends above it.
By their numbers in this assay, from the lowest: compound 3; then compound 1; then compound 2.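

In this assay the stereocentre at the saturated chain carbon matters by itself: drawn S rather than R, it gives a 6.6-fold lower number from compound 1 to compound 3 (0.82 log units; beyond the scatter) as a step, and configuration alone accounts for it because of how the pair is related: the fact that compounds 1 and 3 differ only in the configuration as drawn. With the S configuration kept, ethyl(isopropyl)amino in place of butylamino on an aromatic carbon gives a 44-fold lower number from compound 2 to compound 3 (1.64 log units; beyond the scatter) as a second, large step.

The compounds shown leave open whether the S form also gives the lower number with butylamino. They also leave open how a cyclopropylamino group, or a methoxy group in place of the chlorine, would read.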